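A few compounds are considered here, and "the series" means these few. Any claim that something is new, unique, unknown or untested is made for them only; others in the source may bear on it.

Measured in a functional assay on SW480 cells (Homo sapiens) for antiproliferative activity, read by MTT assay, with a stated time of 48 h; a higher number here means a weaker inhibitor, a lower number a stronger inhibitor:

Compound 1 `CC(C)=CCC[C@]1(C)/C=C/[C@@H](OC(=O)C=C(C)C)[C@](C)(O)/C=C/C(=O)/C(C(=O)O)=C\C1`: > 10000 nM, a limit of the assay
Compound 2 `CC(C)=CCC[C@]1(C)/C=C/[C@@H](OC(=O)C=C(C)C)[C@](C)(O)/C=C/C(=O)/C(CN(C)C)=C\C1`: 480 nM
Compound 3 `CC(C)=CCC[C@]1(C)/C=C/[C@@H](OC(=O)C=C(C)C)[C@](C)(O)/C=C/C(=O)/C(CN(C(C)C)C(C)C)=C\C1`: 750 nM

Compound 3 gives 750 nM and stands level with compound 2, since the step between them is a 1.6-fold higher number from compound 2 to compound 3 (0.19 log units; within the scatter). Compound 1 is known only by its limit, > 10000 nM. Compound 3 is therefore far stronger than compound 1, with an at least 13-fold lower number from compound 1 to compound 3 (1.12 log units; beyond the scatter).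

The next compound to be tested is compound 4 `CC(C)=CCC[C@]1(C)/C=C/[C@@H](OC(=O)C=C(C)C)[C@](C)(O)/C=C/C(=O)/C(CN2CCCC2)=C\C1`, which carries pyrrolidin-1-yl in place of diisopropylamino on a saturated chain carbon bound to a double-bonded ring carbon.

Within the data shown here, the closest precedent is the change at this same place from dimethylamino to diisopropylamino, a 1.6-fold higher number from compound 2 to compound 3 (0.19 log units; within the scatter). The two large steps, an at least 20-fold lower number from compound 1 to compound 2 (1.31 log units; beyond the scatter) and an at least 13-fold lower number from compound 1 to compound 3 (1.12 log units; beyond the scatter), both replace carboxy and so say little about this change, as compound 4 keeps an amino group on the same chain carbon. With only compound 2 and compound 3 as a guide, no step beyond the scatter is anticipated in this assay. The expected step is a 1.4-fold lower number from compound 3 to compound 4 (0.13 log units; within the scatter). For compound 4 the estimated value is 550 nM, with an expected range from 240 nM to 1200 nM.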

Compound 4, half-maximal inhibitory concentration: 310 nM
For compound 4 the middle estimate is 1.8-fold (0.25 log units) above the measured one; the measured number falls inside the stated range.
By their numbers in this assay, from the lowest: compounds 4, 2 and 3 (each within the scatter of the next, the first and the last beyond it). At a limit, above all of these: compound 1.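

In this assay, replacing diisopropylamino with pyrrolidin-1-yl on the saturated chain carbon gives a 2.4-fold lower number from compound 3 to compound 4 (0.38 log units; beyond the scatter) and thus the first modest separation among the amines at this position, where the earlier change gave only a 1.6-fold higher number from compound 2 to compound 3 (0.19 log units; within the scatter) and stayed within the scatter. The ring does not set compound 4 apart from the dimethylamino compound, since the pair shows a 1.5-fold lower number from compound 2 to compound 4 (0.19 log units; within the scatter) and compound 2 lies within the scatter of both other amines, so the three do not form a clean ladder. The amine series now reaches further from the carboxy compound, with an at least 32-fold lower number from compound 1 to compound 4 (1.50 log units; beyond the scatter) as a step that is only a bound, since compound 1 is known by a limit: the limit of > 10000 nM in this assay, at which 1 of the 4 values shown sits.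

The compounds shown do not separate the effect of closing the ring from that of the change from 7 to 5 heavy atoms, and a diethylamino group or a piperidine at the same place would bear on that question. Nor do they show whether the amine nitrogen itself is needed, which a neutral amide or a plain alkyl chain on this carbon could address.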